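From a Methoxy Limit to a Methyl Analogue

The source may hold more compounds than are shown below. What is called first, only, known or untested is meant among the compounds shown, and "the series" means these compounds.

Compound 1 `COc1ccccc1NC(=S)N/N=C/c1ccc2ccccc2n1` gives, in a functional assay on HeLa cells (Homo sapiens) for antiproliferative activity, read by sulforhodamine B assay, with a stated time of 72 h (a higher number here means a weaker inhibitor, a lower number a stronger inhibitor), only the limit > 100000 nM, a boundary of the measurement rather than a number (the limit of > 100000 nM in this assay, at which 1 of the 3 values shown sits). Its nearest measured neighbour, compound 2 `FC(F)(F)c1ccccc1NC(=S)N/N=C/c1ccc2ccccc2n1`, gives 18800 nM in this assay; the change of trifluoromethyl in place of methoxy on an aromatic carbon yields an at least 5.3-fold lower number from compound 1 to compound 2 (0.72 log units; beyond the scatter). Compound 3 `NC(=S)N/N=C/c1cc2cccnc2s1`, built on a different core, gives 6290 nM in this assay. Compound 4 `Cc1cccc(NC(=S)N/N=C/c2ccc3ccccc3n2)c1` has not been measured; it differs from compound 1 by 3-methylphenyl in place of 2-methoxyphenyl on an amide-type nitrogen. Among the measured compounds shown here, only the step from compound 1 to compound 2 bears on it, and only loosely: that step shows that exchanging the group on the aromatic carbon can move the number below the limit seen for compound 1. The methyl change is another such exchange, so compound 4 is expected to show a modest downward step an at least 2.0-fold lower number from compound 1 to compound 4 (0.30 log units; that floor lies within the scatter), though a value remaining at the limit is also plausible. The estimate for compound 4 is 50000 nM, with a range from 12000 nM to 200000 nM.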

Compound 4, half-maximal inhibitory concentration: > 100000 nM
Compound 4 ended at the assay's limit; the forecaster's own chance of this, stated with the estimate: 40%; middle value at least 2.0-fold (0.30 log units) away from the limit.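

In this assay compound 4 gives > 100000 nM, a limit and not a number. Compound 1 gives > 100000 nM, also a limit. Among the compounds shown here, no step between compound 1 and compound 4 can be read. The compounds shown leave open whether 3-methylphenyl and 2-methoxyphenyl on the amide-type nitrogen differ at all in this assay.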